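The source may report more compounds than this note shows. Statements on the series, on what has been measured and on what is new or still open speak of the compounds shown alone.

Working notes on the series.

Three compounds have numbers in a functional assay on L1210 cells (Mus musculus), with a stated time of 12 days; a lower number here means a less potent compound, a higher number a more potent compound, by a factor of ten per unit of this negative logarithm. Compound 1 `O=C1C(CCO)=C(N2CC2)C(=O)C(CCO)=C1N1CC1` gives 6.05. Compound 2 `CC1=C(N2CC2)C(=O)C(CCCOC(N)=O)=C(N2CC2)C1=O` gives 5.93. Compound 3 `CCCC1=C(N2CC2)C(=O)C(CCOC(N)=O)=C(N2CC2)C1=O` gives 5.23. Compound 2 stands second highest of the three: its number sits within the scatter of that of compound 1, so no order between those two can be read, while compound 3 lies below it by a margin beyond the scatter.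

Compound 4 `CCC(OC)C1=C(N2CC2)C(=O)C(C)=C(N2CC2)C1=O` has not been measured in this assay. It differs from compound 2 at a single point: a group of 5 heavy atoms (4 carbon, 1 oxygen; no ring) in place of a group of 7 heavy atoms (4 carbon, 1 nitrogen, 2 oxygen; no ring), on a double-bonded ring carbon. The change sits on a double-bonded ring carbon, next to the ring atom that bears an aziridin-1-yl group and three ring bonds from the ring atom that bears a methyl group.

For the measured compounds named here, no pair of measured compounds differs in only one place, so no single step is available to anchor the expectation. Of the measured set, the lowest number belongs to compound 3, whose chain on the shared core carries a carbamate, while the two compounds that carry a carbamate or a hydroxyl on both chains sit higher. On that limited showing, the step from compound 2 to compound 4 is expected to be a decrease of moderate size, a number 0.53 log units lower from compound 2 to compound 4 (beyond the scatter), though the basis is thin.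

Compound 4 is therefore estimated at 5.4 in this assay, with a range from 4.8 to 6.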

Compound 4, logarithm of the reciprocal of the active concentration, log(1/C): 5.33
The estimate for compound 4 lay 0.07 log units above the measured number; measured number inside the range.
By their numbers in this assay, from the lowest: compounds 3 and 4 (each within the scatter of the next); then compounds 2 and 1 (each within the scatter of the next).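

The step in this assay gives the series its first comparison at a single place: a number 0.60 log units lower from compound 2 to compound 4 (beyond the scatter) and is a modest change on the double-bonded ring carbon next to the ring atom that bears an aziridin-1-yl group. This shows that the number responds to what this position carries, while compound 4 at 5.33 also shows that the 1-methoxypropyl group, with 0 hydrogen-bond donors and 1 hydrogen-bond acceptor, can stand here in place of the group of 7 heavy atoms with its 1 hydrogen-bond donor and 2 hydrogen-bond acceptors. No measurement at hand accounts for the step.

The change replaces the whole group at once, so the compounds shown cannot separate the contributions of its length, its branching and its donor and acceptor counts. Also open, as far as these compounds go, is how the number would move with a primary amine or a carboxylic acid at the end of a chain at this position, or with a longer chain carrying the 1-methoxy pattern, with the methyl group and both aziridin-1-yl groups held as in compound 4.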